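The source may hold more compounds than are shown below. What is called first, only, known or untested is meant among the compounds shown, and "the series" means these compounds.

Compound 1 `COc1cccc(-c2nc3c(=O)[nH]c(C)nc3s2)c1` and compound 2 `Cc1cccc(-c2nc3c(=O)[nH]c(C)nc3s2)c1` share one core and differ in a single place. In an assay on CHO cells for displacement of a labelled ligand from adenosine receptor A1 (Homo sapiens), read by scintillation counting, with a stated time of 120 min, tested at 1 uM (a lower number here means less inhibition, a higher number more inhibition at the concentration tested (going by the name of the read-out)), compound 1 gives 1%, and compound 2 gives 1%. The change between them, (methyl in place of methoxy on an aromatic carbon), produced no change at the digits printed from compound 1 to compound 2 (within the scatter). Compound 3 `COc1cccc(Nc2nc3c(=O)[nH]c(C)nc3s2)c1` carries a different core; the difference between the two cores is not broken down here. In this assay compound 3 gives 8%, which stands within the scatter of both compound 1 and compound 2. Compound 4 `Cc1cccc(Nc2nc3c(=O)[nH]c(C)nc3s2)c1` is the partner of compound 3 in the same way that compound 2 is the partner of compound 1: the change methyl in place of methoxy on an aromatic carbon is the same change, made on the same kind of position. Since the earlier step was no change at the digits printed from compound 1 to compound 2 (within the scatter), the step from compound 3 to compound 4 is expected to be a number 1 percentage points lower from compound 3 to compound 4 (within the scatter), resting on that one earlier pair alone. Compound 4 is therefore estimated to give 7% in this assay, most likely between 0% and 18%.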

Compound 4, a percentage reported as inhibition, at one concentration (the size of the read-out at that concentration, not a potency): 12%
Beside the measured number, compound 4's estimate is 5 percentage points below it; the measured number falls inside the stated range.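

On the other core, methyl in place of methoxy gave a number 4 percentage points higher from compound 3 to compound 4 (within the scatter) in this assay. Set beside the earlier step, the change carries from one core to the other with no difference that stands out from the scatter: the same change on two cores in this assay, no change at the digits printed (within the scatter) from compound 1 to compound 2 and a number 4 percentage points higher (within the scatter) from compound 3 to compound 4, 4 percentage points apart, within the scatter of two such steps. Among these compounds, this shows that the two steps agree in this one read-out, at the single concentration tested, but it rests on only two pairs whose numbers are all small, so it does not show that the swap would carry to a third core, nor that it would behave alike on a compound giving much more inhibition.

The compounds shown carry only methoxy or methyl at this place, so what a chlorine atom, a hydroxyl group, an amine or a longer chain such as ethoxy would give there stays open. Also open, on these data alone, is how these four compounds would read at any other concentration.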